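Chain on the Aromatic Oxygen: From Compound 3 to Compound 4

The source may report more compounds than this note shows. Statements on the series, on what has been measured and on what is new or still open speak of the compounds shown alone.

Three measured compounds share one core and differ only in the chain attached to an oxygen on an aromatic ring. Compound 1 `CCOc1cc(C(C)(C)C)ccc1C/N=C(\S)NCc1ccc(NS(C)(=O)=O)cc1` carries the shortest chain, and in a functional assay for inhibition of Vanilloid receptor (Rattus norvegicus) (on this read-out lower numbers stand for stronger inhibition and higher numbers for weaker inhibition), compound 1 gives 1100 nM. Compound 2 `CCCCCOc1cc(C(C)(C)C)ccc1C/N=C(\S)NCc1ccc(NS(C)(=O)=O)cc1` carries a pentyl chain, and in this assay compound 2 gives 70 nM. Compound 3 `CC(C)Oc1cc(C(C)(C)C)ccc1C/N=C(\S)NCc1ccc(NS(C)(=O)=O)cc1` carries an isopropyl group, and in this assay compound 3 gives 350 nM, the second highest of the three numbers. Compound 4 `CC(C)(C)COc1cc(C(C)(C)C)ccc1C/N=C(\S)NCc1ccc(NS(C)(=O)=O)cc1` has not yet been measured; the change from compound 3 is neopentyl in place of isopropyl on an oxygen on an aromatic ring.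

Among the measured compounds shown here, three measured steps bear on this change. Adding carbons to the chain gave a 16-fold lower number from compound 1 to compound 2 (1.20 log units; beyond the scatter) and a 3.1-fold lower number from compound 1 to compound 3 (0.50 log units; beyond the scatter), while the move from a pentyl chain to isopropyl gave a 5.0-fold higher number from compound 2 to compound 3 (0.70 log units; beyond the scatter). Neopentyl brings the same count of carbons as pentyl, though in a branched chain, so a lower number is expected for compound 4, likely not closing the full gap, because a 5.0-fold higher number from compound 2 to compound 3 (0.70 log units; beyond the scatter) involved a straight chain. Compound 4 is therefore estimated at 120 nM, with a range from 50 nM to 300 nM. The expected step is a 2.9-fold lower number from compound 3 to compound 4 (0.46 log units; beyond the scatter).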

Compound 4, half-maximal inhibitory concentration: 60 nM
Compound 4: the middle estimate sits 2.0-fold (0.30 log units) above what was measured; the measured number falls inside the stated range.
By their numbers in this assay, from the lowest: compounds 4 and 2 (each within the scatter of the next); then compound 3; then compound 1.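

Carbon count matters more here than chain shape: in this assay, neopentyl in place of isopropyl on the aromatic oxygen gives a 5.8-fold lower number from compound 3 to compound 4 (0.77 log units; beyond the scatter), a clear gain from a branched chain that the earlier straight-chain pentyl result could not demonstrate. Comparing the two five-carbon chains gives a 1.2-fold lower number from compound 2 to compound 4 (0.07 log units; within the scatter), so the branched neopentyl and the straight pentyl cannot be told apart on this read-out, and pentyl is not the only chain that reaches this level. The step from the shortest chain gives an 18-fold lower number from compound 1 to compound 4 (1.26 log units; beyond the scatter), a large change that matches the size of the earlier gain with pentyl, but no measurement on hand explains why these chains behave as they do.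

The compounds shown stop at chains of five carbons, leaving open whether a longer chain such as hexyl or octyl would lower the number further or raise it again. They also leave open how a chain ending in a ring, such as benzyl, or one carrying an amine or a carboxylic acid would behave at this oxygen.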